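Changing the Ring on the Sulfonyl Group of Compound 3

A few compounds are considered here, and "the series" means these few. Any claim that something is new, unique, unknown or untested is made for them only; others in the source may bear on it.

Among the compounds with values here, in a functional assay on A2780 cells (Homo sapiens) for antiproliferative activity, read by sulforhodamine B assay, with a stated time of 72 h (a lower number here means a stronger inhibitor, a higher number a weaker inhibitor), compound 3 (`C[C@@H]1COC[C@@H](C)N1S(=O)(=O)c1ccc(NC(=O)NCc2cccnc2)cc1`) gives 745 nM as the only true number so far. Compound 1 (`Cc1ncccc1CNC(=O)Nc1ccc(S(=O)(=O)c2ccccc2)cc1`) reads > 2000 nM as a limit, not a number. Compound 2 (`O=C(NCc1ccc(Cl)nc1)Nc1ccc(S(=O)(=O)c2ccccc2)cc1`) also reads > 2000 nM as a limit. Within the data shown here, the one measured step, a step that the two limits leave unreadable from compound 1 to compound 2, concerns a different group and has no readable size, so it offers no guide. Compound 4 (`CC1CCN(S(=O)(=O)c2ccc(NC(=O)NCc3cccnc3)cc2)CCN1`) changes the group on the sulfonyl sulfur: a group of 8 heavy atoms (6 carbon, 2 nitrogen; one seven-membered non-aromatic ring with 2 hetero atoms) in place of a group of 8 heavy atoms (6 carbon, 1 nitrogen, 1 oxygen; one six-membered non-aromatic ring with 2 hetero atoms), on a sulfonyl sulfur. A lean toward weaker inhibition is expected because the limit of > 2000 nM in this assay, at which 2 of the 3 values shown sit, is the commonest result so far, with compound 3 the exception. The expected size stays modest, a 1.3-fold higher number from compound 3 to compound 4 (0.13 log units; within the scatter), and is only an estimate. In this assay the expected value for compound 4 is 1000 nM, with an estimated range of 300 nM to 3000 nM here.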

Compound 4, half-maximal inhibitory concentration: 109 nM
Compound 4: the middle estimate sits 9.2-fold (0.96 log units) above what was measured, outside the stated range (below it).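

The group on the sulfonyl sulfur clearly matters: in this assay the swap gives a 6.8-fold lower number from compound 3 to compound 4 (0.83 log units; beyond the scatter) as a step beyond the scatter. Within the data shown here, the only earlier step cannot be read because both of its values are limits, so this is the one readable size. The swap changes the ring size, replaces the ring oxygen with nitrogen, adds a hydrogen-bond donor and removes the 2 defined stereocentres, and nothing measured here explains the gain.

Which of these changes counts remains open. A piperazine or an open-chain amine on the sulfonyl sulfur would help separate them.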